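Cyclopentyl to cyclohexyl on the ether chain of a chalcone

The source may report more compounds than this note shows. Statements on the series, on what has been measured and on what is new or still open speak of the compounds shown alone.

Compound 1 `COc1cccc(OCCC(C)(C)C)c1C(=O)/C=C/c1ccc(O)cc1`: > 30000 nM
Compound 2 `O=C(/C=C/c1ccc(O)cc1)c1c(O)cccc1OCCC1CCCC1`: 3340 nM
Compound 3 `CC(C)(C)CCOc1cccc(O)c1C(=O)CCc1ccc(O)cc1`: > 30000 nM

Among the measured compounds shown here, compound 2 is the only member of the set with a measured number in a functional assay on MDA-MB-231 cells (Homo sapiens) for antiproliferative activity, read by sulforhodamine B assay; a higher number here means a weaker inhibitor of growth, a lower number a stronger inhibitor of growth; for compound 1 the assay reports only a limit, > 30000 nM. For compound 3 the result is likewise a limit, > 30000 nM. This is the limit described by the limit of > 30000 nM in this assay, at which 2 of the 3 values shown sit. Compound 4 `O=C(/C=C/c1ccc(O)cc1)c1c(O)cccc1OCCC1CCCCC1` differs from compound 2 in one place: cyclohexyl in place of cyclopentyl on a saturated chain carbon, two bonds along the chain from an oxygen on an aromatic ring. For the measured compounds named here, no measured step of this kind exists among the three compounds, so the account can only expect that the step from compound 2 to compound 4 stays within the usual scatter in this assay, with no clear direction. Compound 4 is therefore estimated at 2800 nM, between 900 nM and 9000 nM, a step of a 1.2-fold lower number from compound 2 to compound 4 (0.08 log units; within the scatter).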

Compound 4, concentration for 50% growth inhibition: > 30000 nM
Compound 4: only a limit was reported (the forecaster's own chance of this, stated with the estimate: 10%); middle value at least 10-fold (1.02 log units) from the limit.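

On a saturated chain carbon, two bonds along the chain from an oxygen on an aromatic ring, the change from cyclopentyl to cyclohexyl is not neutral: in this assay it gives an at least 8.9-fold higher number from compound 2 to compound 4 (0.95 log units; beyond the scatter). Among the compounds shown here, the earlier compounds offered no step at this position, so this is the first sign that the ring carried there matters. The full size of the step cannot be read because compound 4 reaches only a limit: the limit of > 30000 nM in this assay, at which 3 of the 4 values shown sit.

The compounds shown leave open whether a cyclobutyl group or a piperidine ring in this place would keep the activity of compound 2.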